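A few compounds are considered here, and "the series" means these few. Any claim that something is new, unique, unknown or untested is made for them only; others in the source may bear on it.

Of the compounds shown here, three sharing most of one skeleton have been tested, and a fourth awaits measurement. Compound 1 `CCn1cc(-c2nc3ccc([N+](=O)[O-])cc3[nH]2)c(=O)c2cc(F)c(N3CCNCC3)cc21` carries a nitro group on its fused aromatic ring; compound 3 `CCn1cc(-c2nc3ccc(N)cc3[nH]2)c(=O)c2cc(F)c(N3CCNCC3)cc21` is the same molecule except for one exchange: amino in place of nitro on an aromatic carbon. Compound 2 `CCn1cc(-c2nc3ccc([N+](=O)[O-])cc3[nH]2)c(=O)c2cc(F)c(N3CCNCC3)nc21` keeps the nitro group of compound 1 but has a different core, and the difference between the two cores is not broken down here. Compound 4 `CCn1cc(-c2nc3ccc(N)cc3[nH]2)c(=O)c2cc(F)c(N3CCNCC3)nc21` relates to compound 2 as compound 3 relates to compound 1: amino in place of nitro on an aromatic carbon.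

In a functional assay on Bel-7402 cells (Homo sapiens) for cytotoxicity, read by MTT assay, with a stated time of 48 h (a lower number here means a stronger inhibitor, a higher number a weaker inhibitor), compound 1 gives 2100 nM. In this assay compound 3 gives 92100 nM, so the exchange made a 44-fold higher number from compound 1 to compound 3 (1.64 log units; beyond the scatter). In this assay compound 2 gives 10800 nM, a higher number than that of compound 1, so with the nitro group in place the core of compound 2 is the weaker of the two.

The change from compound 2 to compound 4 is the same change as from compound 1 to compound 3, at a place described in the same words. Within the data shown here, only that one step has been measured, so the expectation rests on it alone. The step is expected to be similar, a 32-fold higher number from compound 2 to compound 4 (1.51 log units; beyond the scatter), because the measured step was a 44-fold higher number from compound 1 to compound 3 (1.64 log units; beyond the scatter). Compound 4 is therefore expected to give about 350000 nM in this assay, most likely between 90000 nM and 1200000 nM, and so high a number may come back only as a limit rather than as a value.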

Compound 4, half-maximal inhibitory concentration: 93300 nM
Compound 4: the middle estimate sits 3.8-fold (0.57 log units) above what was measured; measured number inside the range.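

Exchanging nitro for amino raised the number on the second core as it did on the first, an 8.6-fold higher number from compound 2 to compound 4 (0.94 log units; beyond the scatter), so in this assay the direction of the change carried over from one core to the other. The size of the change did not carry over, and the core therefore has to be taken into account when this step is used for a forecast: the same change on two cores in this assay, a 44-fold higher number (1.64 log units; beyond the scatter) from compound 1 to compound 3 and an 8.6-fold higher number (0.94 log units; beyond the scatter) from compound 2 to compound 4, 5.1-fold (0.71 log units) apart, beyond the scatter of two such steps. Compound 3 gives 92100 nM and compound 4 gives 93300 nM, so the two amino compounds land close together whichever core they carry, but two pairs cannot show why the step is smaller on the second core or whether a third core would follow either one.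

The compounds shown leave open what other groups on the same aromatic carbon would give on each core, for example a hydrogen, a chlorine, a nitrile or an acetamido group. They also leave open whether such groups would fall in the same order on both cores, or whether their steps would differ from one core to the other as the amino step does.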